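Compound 3 to compound 4: 4-methylphenyl to phenyl

A few compounds are considered here, and "the series" means these few. Any claim that something is new, unique, unknown or untested is made for them only; others in the source may bear on it.

Of the compounds shown here, three on a shared core have been measured so far: compound 1 `Cc1cccc(CN(C)C(=O)c2cc(Cl)c(O)cc2O)c1`, compound 2 `CCNC(=O)c1ccc(CN(C)C(=O)c2cc(Cl)c(O)cc2O)cc1` and compound 3 `Cc1ccc(CN(C)C(=O)c2cc(Cl)c(O)cc2O)cc1`. In a functional assay on NCI-H1975 cells (Homo sapiens) for antiproliferative activity, with a stated time of 72 h (on this read-out higher numbers stand for weaker inhibition of growth and lower numbers for stronger inhibition of growth), compound 1 gives 49300 nM, compound 2 gives 21700 nM and compound 3 gives 34300 nM. Compound 3 therefore stands within the scatter of both other compounds. Compound 4 `CN(Cc1ccccc1)C(=O)c1cc(Cl)c(O)cc1O` has hydrogen in place of methyl on an aromatic carbon, para to a large group: hydrogen in place of methyl on an aromatic carbon.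

Among the compounds with values here, two measured steps bear on this change. The first, 4-methylphenyl in place of 3-methylphenyl, is a 1.4-fold lower number from compound 1 to compound 3 (0.16 log units; within the scatter). The second, methyl in place of ethylcarbamoyl on an aromatic carbon, is a 1.6-fold higher number from compound 2 to compound 3 (0.20 log units; within the scatter). Neither step measures the loss of the methyl directly, but both stay within the scatter. No change beyond the scatter is therefore expected in this assay, in either direction. The estimated step is a 1.2-fold higher number from compound 3 to compound 4 (0.07 log units; within the scatter). Compound 4 is expected at 40000 nM, with an estimated range of 19000 nM to 80000 nM.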

Compound 4, concentration for 50% growth inhibition: 35500 nM
Estimate against measurement, compound 4: 1.1-fold (0.05 log units) above; the measured number falls inside the stated range.
By their numbers in this assay, from the lowest: compounds 2, 3, 4 and 1 (each within the scatter of the next, the first and the last beyond it).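

In this assay, the first direct test of the methyl at this place, on an aromatic carbon para to a large group, shows that its removal leaves the number within the scatter (a 1.0-fold higher number from compound 3 to compound 4 (0.01 log units; within the scatter)). The unsubstituted phenyl of compound 4 also stays within the scatter of the ethylcarbamoyl group of compound 2 (a 1.6-fold higher number from compound 2 to compound 4 (0.21 log units; within the scatter)) and of the 3-methylphenyl group of compound 1 (a 1.4-fold lower number from compound 1 to compound 4 (0.14 log units; within the scatter)), so none of the three substituted rings separates from it in this assay. No measured evidence accounts for this flat result.

Still open, on these data alone, is whether a primary amine, a carboxylic acid or a longer chain on this aromatic carbon would move the number beyond the scatter. As far as these compounds go, the shared core itself stays unvaried across these compounds, so its contribution remains unknown.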